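The source may hold more compounds than are shown below. What is called first, only, known or untested is meant among the compounds shown, and "the series" means these compounds.

Of the compounds shown here, three built on one shared core have so far been measured in an assay on isolated protein for displacement of a labelled ligand from metabotropic glutamate receptor 5 (Homo sapiens), with a stated time of 60 min, tested at 1 uM; a lower number here means less inhibition, a higher number more inhibition at the concentration tested (going by the name of the read-out). Compound 1 `Cc1ccc(S(=O)(=O)c2cnc3ccc(Cl)cc3c2N2CCC(C)CC2)cc1C` gives 84%, compound 2 `CC1CCN(c2c(S(=O)(=O)c3ccc(Cl)c(Cl)c3)cnc3ccc(Cl)cc23)CC1` gives 86%, and compound 3 `COc1ccc2ncc(S(=O)(=O)c3ccc(Cl)c(Cl)c3)c(N3CCC(C)CC3)c2c1` gives 87%. On these numbers compound 3 sits at the top of the three, yet each gap between it and the others lies within the scatter, so the three cannot really be told apart. The two single-point steps say the same: a number 2 percentage points higher from compound 1 to compound 2 (within the scatter), and a number 1 percentage points higher from compound 2 to compound 3 (within the scatter).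

Compound 4 `COc1ccc2ncc(S(=O)(=O)c3ccc(C)cc3)c(N3CCC(C)CC3)c2c1` has not yet been measured. It differs from compound 3 in one place: 4-methylphenyl in place of 3,4-dichlorophenyl on a sulfonyl sulfur. For the measured compounds named here, of the measured steps, only the one from compound 1 to compound 2 bears on this, since it also exchanged the group on the sulfonyl sulfur, there putting 3,4-dichlorophenyl in place of 3,4-dimethylphenyl, and that exchange gave a number 2 percentage points higher from compound 1 to compound 2 (within the scatter). The exchange now removes the dichloro group and brings in 4-methylphenyl, and the earlier step suggests that swaps of this kind on the sulfur hardly move the read-out. No change beyond the scatter is therefore expected in this assay, and the step from compound 3 to compound 4 is estimated as a number 4 percentage points lower from compound 3 to compound 4 (within the scatter). Compound 4 is thus expected to give about 83%, within a range from 70% to 92%.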

Compound 4, a percentage reported as inhibition, at one concentration (the size of the read-out at that concentration, not a potency): 90%
Beside the measured number, compound 4's estimate is 7 percentage points below it; measured number inside the range.
By their numbers in this assay, from the lowest: compounds 1, 2, 3 and 4 (each within the scatter of the next).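

The change at the sulfonyl sulfur gives a number 3 percentage points higher from compound 3 to compound 4 (within the scatter) in this assay, so the read-out stays within the scatter even though the aromatic group now carries no chlorine at all. The earlier step on this sulfur only exchanged 3,4-dimethylphenyl and 3,4-dichlorophenyl, whereas this one shows that 4-methylphenyl, with 7 heavy atoms in place of 8, also fits the same narrow band of values, and on a core bearing methoxy rather than chloro. Nothing in the data given explains why these exchanges leave the number so little changed.

All four compounds remain within the scatter of their neighbours at a single tested concentration, so the compounds shown reveal no change at this position that clearly alters the read-out, and they cannot rank the groups by potency. From the compounds shown here alone, it remains open whether an amine or a carboxylic acid on the aromatic ring attached to the sulfonyl sulfur, or a longer alkyl chain in place of the methyl of 4-methylphenyl, would move the number beyond the scatter.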